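A few compounds are considered here, and "the series" means these few. Any claim that something is new, unique, unknown or untested is made for them only; others in the source may bear on it.

Measured so far:
Compound 1, `CC(=O)c1cc(-c2ccccc2)cc2cc(-c3ccc(F)cc3)[nH]c12`, gives > 100000 nM in a functional assay on MCF7 cells (Homo sapiens) for cytotoxicity, read by MTT assay, with a stated time of 2 days; a lower number here means that less compound is tolerated, a higher number that more compound is tolerated.
Compound 2, `COc1ccc(-c2cc(C(C)=O)c3[nH]c(-c4ccc(F)cc4)cc3c2)cc1`, gives 16800 nM in this assay.

The value for compound 1 is a limit of the assay rather than a number, as the entry the limit of > 100000 nM in this assay, at which 1 of the 2 values shown sits, records. Among the compounds with values here, compound 2 therefore stands as the only compound with an actual number in this assay; the one further value is that limit. Within the data shown here, the single measured step, an at least 5.9-fold lower number from compound 1 to compound 2 (0.77 log units; beyond the scatter), came from putting methoxy in place of hydrogen on an aromatic carbon.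

Compound 3, `COc1ccc(-c2cc(C(C)=O)c3[nH]c(-c4ccc(OC)cc4)cc3c2)cc1`, is not yet measured. It differs from compound 2 as follows: methoxy in place of fluoro on an aromatic carbon. The measured step concerned a methoxy arriving at a different place, so it is only a loose guide, but it is the one available. Compound 3 is expected to show a small step, at most modest and toward a lower number, a 1.5-fold lower number from compound 2 to compound 3 (0.18 log units; within the scatter). The estimate for compound 3 in this assay is 11000 nM, with a range from 3500 nM to 40000 nM.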

Compound 3, concentration lethal to 50% of the cells: 25200 nM
Beside the measured number, compound 3's estimate is 2.3-fold (0.36 log units) below it, and the stated range covers the measured number.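

In this assay, going from 4-fluorophenyl to 4-methoxyphenyl gives a 1.5-fold higher number from compound 2 to compound 3 (0.18 log units; within the scatter), which means that this exchange at this position does not separate compound 2 from compound 3. The earlier step, which put methoxy in place of hydrogen at a different place, gave an at least 5.9-fold lower number from compound 1 to compound 2 (0.77 log units; beyond the scatter), and it lay beyond the scatter. Methoxy therefore did not read the same in the two steps, although each place rests on one step and the group replaced was different each time.

Whether any group at the position of the fluoro can move the number beyond the scatter remains open, as an amine, a carboxylic acid or a longer chain such as butoxy is not among these compounds. The entry for compound 1 is a limit of the assay and not a number, and the full size of the step from it also remains open: the limit of > 100000 nM in this assay, at which 1 of the 3 values shown sits.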